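A few compounds are considered here, and "the series" means these few. Any claim that something is new, unique, unknown or untested is made for them only; others in the source may bear on it.

Measured so far:
Compound 1, `COC(=O)c1ccc(C2SCC(=O)N2c2ccc(N3CCN(Cc4cccc([N+](=O)[O-])c4)CC3)cn2)c(OC)c1`, gives > 100000 nM in a functional assay on NALM-6 cells (Homo sapiens) for antiproliferative activity, read by MTT assay and trypan blue exclusion, with a stated time of 72 h; a higher number here means a weaker inhibitor, a lower number a stronger inhibitor.
Compound 2, `COC(=O)c1ccc(C2SCC(=O)N2c2ccc(N3CCN(Cc4ccc(Cl)c(Cl)c4)CC3)cn2)c(OC)c1`, gives > 100000 nM in this assay.

The value for compound 1 is a limit of the assay, not a number. The value for compound 2 is likewise a limit of the assay and not a number. Both sit at the limit of > 100000 nM in this assay, at which 2 of the 2 values shown sit, so compound 2 stands at the limit itself, with nothing above or below it to rank against. Among the compounds with values here, the only measured step, a step that the two limits leave unreadable from compound 1 to compound 2, is therefore unreadable: two limits cannot show whether anything changed.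

Compound 3, `COC(=O)c1ccc(C2SCC(=O)N2c2ccc(N3CCN(S(=O)(=O)c4ccccc4)CC3)cn2)c(OC)c1`, differs from compound 2 in one place: phenylsulfonyl in place of 3,4-dichlorobenzyl on an amine nitrogen in a ring. Within the data shown here, the single measured step bears on this same position, but it gives no size and no direction, so no size of change in this assay can be expected from it beyond the chance that compound 3 again reaches only the limit. Compound 3 is therefore estimated at 100000 nM, with a range from 20000 nM to 300000 nM. The implied step a number no higher from compound 2 to compound 3 (the limit leaves the size open) is expected to be essentially none, with a real measurement quite possibly reported only as a limit.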

Compound 3, half-maximal inhibitory concentration: 48400 nM
Beside the measured number, compound 3's estimate is 2.1-fold (0.32 log units) above it; the measured number falls inside the stated range.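

The group on the ring nitrogen can move the read-out in this assay, which the earlier pair could not show: phenylsulfonyl gives an at least 2.0-fold lower number from compound 2 to compound 3 (0.31 log units; beyond the scatter), and set against the 3-nitrobenzyl group the same change gives an at least 2.0-fold lower number from compound 1 to compound 3 (0.31 log units; beyond the scatter). Compound 1 and compound 2 each remain at a limit of the assay, not a number, so these steps have only a lower bound on their size: the limit of > 100000 nM in this assay, at which 2 of the 3 values shown sit. With compound 3 at 48400 nM, this position now has its first real number, and the entering phenylsulfonyl counts 2 hydrogen-bond acceptors where the 3,4-dichlorobenzyl counts 0, although one change cannot link that difference to the drop.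

The compounds shown leave open whether the sulfonyl link or the phenyl ring attached to it matters more, a question that a methylsulfonyl or a benzoyl group on the same ring nitrogen could help to answer. They also leave open whether the number would fall further with a chlorine or a methoxy group on the phenyl ring of the phenylsulfonyl group.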